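Aryl variation on the ring amine: compound 3 to compound 4

A few compounds are considered here, and "the series" means these few. Any claim that something is new, unique, unknown or untested is made for them only; others in the source may bear on it.

Compound 3 `CC(C)C1(C(C)C)NC(=O)N(CN2CCN(c3ccc(F)cc3)CC2)C1=O` is measured in a functional assay on the whole organism (strain CD1) with Mus musculus as the target, in the maximal electroshock model, with a stated time of 4 h (a higher number here means that more compound is needed for the effect, a lower number that less compound is needed), at 100 mg/kg. Compound 1 `CC(C)C1(C(C)C)NC(=O)N(CN2CCN(c3cccc(C(F)(F)F)c3)CC2)C1=O` gives 100 mg/kg and compound 2 `O=C1NC(c2ccccc2)(c2ccccc2)C(=O)N1CN1CCN(c2ccccc2)CC1` gives 100 mg/kg, so compound 3 stands level with both within the scatter. The step of no change at the digits printed from compound 1 to compound 3 (within the scatter) shows that exchanging one aryl group for another on the ring amine nitrogen left the read-out unchanged. Compound 4 `CC(C)C1(C(C)C)NC(=O)N(CN2CCN(c3cccc(Cl)c3)CC2)C1=O` differs from compound 3 by 3-chlorophenyl in place of 4-fluorophenyl on an amine nitrogen in a ring. Among the measured compounds shown here, only the step from compound 1 to compound 3 bears on this change, and it was flat, so no shift beyond the scatter is anticipated in this assay. For compound 4 the expected step is no change at the digits printed from compound 3 to compound 4 (within the scatter). Compound 4 is therefore estimated at 100 mg/kg, with a range of 50 mg/kg to 200 mg/kg.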

Compound 4, minimum effective dose: 100 mg/kg
Beside the measured number, compound 4's estimate shows no gap at the digits printed, and the stated range covers the measured number.
By their numbers in this assay, from the lowest: compounds 1, 2, 3 and 4 (each within the scatter of the next).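

In this assay, 3-chlorophenyl in place of 4-fluorophenyl on an amine nitrogen in a ring gives no change at the digits printed from compound 3 to compound 4 (within the scatter) and thus extends the flat picture to a third aryl group. Chloro in place of trifluoromethyl on an aromatic carbon gives no change at the digits printed from compound 1 to compound 4 (within the scatter) as a further reading, this time of a single substituent exchange. The data offer no explanation for these flat steps.

As far as these compounds go, whether a carboxylic acid or an amine on the aryl ring would move the read-out remains open. So does the effect of a longer alkyl chain in place of the aryl group.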